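Heteroaryl exchange at the ring amine: expectation for compound 4

A few compounds are considered here, and "the series" means these few. Any claim that something is new, unique, unknown or untested is made for them only; others in the source may bear on it.

Going by the values given here, the three measured members share one core and differ only in the heteroaryl group on a saturated chain carbon bound to an amine nitrogen in a ring. Compound 1 `Cc1nc(C)c(CN2CCN(c3cccc4[nH]c(-c5ccc(C(C)(C)C)cc5)nc34)CC2)o1` carries 2,4-dimethyl-1,3-oxazol-5-yl there and in an assay on isolated protein for displacement of a labelled ligand from Gonadotropin-releasing hormone receptor (Rattus norvegicus) (a lower number here means a stronger inhibitor, a higher number a weaker inhibitor), compound 1 gives 740 nM. Compound 2 `CCc1cc(CN2CCN(c3cccc4[nH]c(-c5ccc(C(C)(C)C)cc5)nc34)CC2)nn1C` carries 5-ethyl-1-methyl-1H-pyrazol-3-yl and in this assay compound 2 gives 350 nM. Compound 3 `CCCCn1cnc(CN2CCN(c3cccc4[nH]c(-c5ccc(C(C)(C)C)cc5)nc34)CC2)c1C` carries 1-butyl-5-methyl-1H-imidazol-4-yl and in this assay compound 3 gives 49 nM. Compound 2 thus stands second highest of the three: a 2.1-fold lower number from compound 1 to compound 2 (0.33 log units; beyond the scatter), a 7.1-fold lower number from compound 2 to compound 3 (0.85 log units; beyond the scatter), and across the whole set a 15-fold lower number from compound 1 to compound 3 (1.18 log units; beyond the scatter).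

Compound 4 `CCCCc1nc(CN2CCN(c3cccc4[nH]c(-c5ccc(C(C)(C)C)cc5)nc34)CC2)cn1C` is not yet measured. The change from compound 2 is 2-butyl-1-methyl-1H-imidazol-4-yl in place of 5-ethyl-1-methyl-1H-pyrazol-3-yl on a saturated chain carbon bound to an amine nitrogen in a ring. Among the compounds with values here, the step that bears on it most directly is a 7.1-fold lower number from compound 2 to compound 3 (0.85 log units; beyond the scatter), which likewise replaces the pyrazolyl group with a butyl-bearing five-membered ring with two hetero atoms; however, the placement of butyl and methyl on that ring differs between compound 3 and compound 4, and no measured step covers exactly this arrangement. A lower number in this assay is therefore expected for compound 4, with the expected step of a 3.2-fold lower number from compound 2 to compound 4 (0.50 log units; beyond the scatter) set smaller than a 7.1-fold lower number from compound 2 to compound 3 (0.85 log units; beyond the scatter). The match to compound 3 is only partial. Compound 4 is estimated at 110 nM in this assay, expected within 35 nM to 350 nM.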

Compound 4, half-maximal inhibitory concentration: 58 nM
The estimate for compound 4 lay 1.9-fold (0.28 log units) above the measured number; measured number inside the range.
By their numbers in this assay, from the lowest: compounds 3 and 4 (each within the scatter of the next); then compound 2; then compound 1.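

In this assay, going by these compounds alone, the 2-butyl-1-methyl-1H-imidazol-4-yl group gives a 6.0-fold lower number from compound 2 to compound 4 (0.78 log units; beyond the scatter) and a 13-fold lower number from compound 1 to compound 4 (1.11 log units; beyond the scatter) at this position on a saturated chain carbon bound to an amine nitrogen in a ring, so compound 3 is no longer the only member well below compound 1 and compound 2. The exchange of the two butyl-bearing imidazolyl groups gives a 1.2-fold higher number from compound 3 to compound 4 (0.07 log units; within the scatter) and the assay does not tell them apart, which shows that the lower number survives this rearrangement of the butyl and methyl groups on the imidazolyl ring. Among these four compounds, both butyl-bearing imidazolyl groups give lower numbers than the pyrazolyl and oxazolyl groups, and no data shown here explain the steps.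

The compounds shown leave open whether the imidazolyl ring or the butyl chain carries the step, since the change from compound 2 alters both at once; a 5-butyl-1-methyl-1H-pyrazol-3-yl group or a 2-ethyl-1-methyl-1H-imidazol-4-yl group would separate the two. They also leave open how a longer chain such as hexyl, or a butyl chain ending in an amine or a carboxylic acid, would read at this position.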